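This account rests on a few compounds, and the source may have more. Where it says the series, first, only, none or still open, it means among the compounds named here.

Measured compounds:
- compound 1 `N/C(=N/O)c1ccc(C2=C(S(=O)(=O)c3ccc(F)cc3)CC(c3ccccc3)(c3ccccc3)O2)cc1`: 19200 nM
- compound 2 `CC1(c2ccc(-c3ccco3)cc2)CC(S(=O)(=O)c2ccc(F)cc2)=C(c2ccc(/C(N)=N\O)cc2)O1`: 7010 nM
- compound 3 `CC1(c2ccccc2)CC(S(=O)(=O)c2ccc(F)cc2)=C(c2ccc(/C(N)=N\O)cc2)O1`: 68300 nM

These three compounds share one core and were tested in an ADME assay on HepG2 cells (Homo sapiens) for cytotoxicity, read by MTT assay, with a stated time of 72 h; a lower number here means that less compound is tolerated, a higher number that more compound is tolerated. Compound 3 stands highest of the three: the step of a 3.6-fold higher number from compound 1 to compound 3 (0.55 log units; beyond the scatter) and the step of a 9.7-fold higher number from compound 2 to compound 3 (0.99 log units; beyond the scatter) both lead up to it, and both lie beyond the scatter, so compound 3 is the one whose highest amount is tolerated among these.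

Compound 4 `COc1ccc(C2(c3ccccc3)CC(S(=O)(=O)c3ccc(F)cc3)=C(c3ccc(/C(N)=N\O)cc3)O2)cc1` has not yet been measured. It differs from compound 3 in one place: 4-methoxyphenyl in place of methyl on a saturated ring carbon. The step that bears most directly on this change is a 3.6-fold higher number from compound 1 to compound 3 (0.55 log units; beyond the scatter), where a methyl took the place of a phenyl at the same saturated ring carbon; going the other way, from methyl to a six-membered aromatic ring at that position, would mean a lower number. The step of a 9.7-fold higher number from compound 2 to compound 3 (0.99 log units; beyond the scatter) is at a different place, but it too shows the number rising when a ring leaves. For compound 4, which gains a 4-methoxyphenyl at the saturated ring carbon, a lower number than compound 3 is therefore expected, of modest size, with the estimated step of a 4.6-fold lower number from compound 3 to compound 4 (0.66 log units; beyond the scatter). The estimate for compound 4 in this assay is 15000 nM, with a range from 5000 nM to 45000 nM.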

Compound 4, half-maximal cytotoxic concentration: 29400 nM
Compound 4: the middle estimate sits 2.0-fold (0.29 log units) below what was measured; the range from low to high includes it.
By their numbers in this assay, from the lowest: compound 2; then compounds 1 and 4 (each within the scatter of the next); then compound 3.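

In this assay, 4-methoxyphenyl in place of methyl on the saturated ring carbon next to the ring oxygen gives a 2.3-fold lower number from compound 3 to compound 4 (0.37 log units; beyond the scatter), so a substituted aromatic ring at this carbon also goes with a lower number than methyl, as the plain phenyl of compound 1 did. The methoxy group itself makes no readable difference here: the step for methoxy in place of hydrogen on the aromatic carbon is a 1.5-fold higher number from compound 1 to compound 4 (0.19 log units; within the scatter), which lies within the scatter, so compound 1 and compound 4 cannot be told apart in this assay. Nothing among the data shown explains why an aromatic ring at this position goes with a lower number.

From the compounds shown here alone, it remains open whether the aromatic ring matters or whether any larger group would do the same, which a cyclohexyl ring or a longer chain such as butyl at this carbon could test. Going by these compounds, it is also open whether the tolerance of methoxy on this ring extends to very different groups at the same spot, such as an amine or a carboxylic acid.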